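Carboxy for Hydroxy on Two Quinoline-Type Amide Cores

A few compounds are considered here, and "the series" means these few. Any claim that something is new, unique, unknown or untested is made for them only; others in the source may bear on it.

Measured compounds:
compound 1, `Cc1c(C(=O)Nc2c(F)cc(-c3cccc(F)c3)cc2F)nc2ccc(C(F)(F)F)cc2c1O`, -0.33%;
compound 2, `COc1ccc2nc(C(=O)Nc3ccc(-c4ccccc4)cc3)c(C)c(O)c2c1`, 0.35%;
compound 3, `Cc1c(C(=O)Nc2c(F)cc(-c3cccc(F)c3)cc2F)nc2ccc(C(F)(F)F)cc2c1C(=O)O`, 0.2%.

All three were tested in a functional assay on Hep 3B2 cells (Homo sapiens) for antiproliferative activity, read by MTT assay, with a stated time of 24 h, tested at 0.01 ug/mL; a lower number here means a weaker effect, a higher number a stronger effect of the compound at the concentration tested. Compound 1 and compound 3 share a core and differ in one place: carboxy in place of hydroxy on an aromatic carbon. The step of a number 0.5 percentage points higher from compound 1 to compound 3 (within the scatter). Compound 2 carries a different core; how the two cores differ is not broken down here. Compound 4, `COc1ccc2nc(C(=O)Nc3ccc(-c4ccccc4)cc3)c(C)c(C(=O)O)c2c1`, is not yet measured; it stands to compound 2 as compound 3 stands to compound 1, the same change at the same place: carboxy in place of hydroxy on an aromatic carbon. In this assay compound 2 gives 0.35%, and none of the three measured values are apart by more than the scatter. The step from compound 2 to compound 4 is expected to be a number 0.3 percentage points higher from compound 2 to compound 4 (within the scatter), essentially no change, because the earlier step of a number 0.5 percentage points higher from compound 1 to compound 3 (within the scatter) stayed within the scatter. Compound 4 is therefore estimated at 0.6%, between -9% and 10%.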

Compound 4, a percentage reported as inhibition, at one concentration (the size of the read-out at that concentration, not a potency): -0.12%
Beside the measured number, compound 4's estimate is 0.7 percentage points above it; the measured number falls inside the stated range.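

In this assay, carboxy in place of hydroxy on the aromatic carbon gives a number 0.5 percentage points lower from compound 2 to compound 4 (within the scatter). Set beside the same change on the core of compound 1, the two cores cannot be told apart: the same change on two cores in this assay, a number 0.5 percentage points higher (within the scatter) from compound 1 to compound 3 and a number 0.5 percentage points lower (within the scatter) from compound 2 to compound 4, 1 percentage points apart, within the scatter of two such steps. This shows that the change left no readable mark on either core at this one concentration, but with all four values lying close to zero, it does not show that the change would stay neutral in a compound with a clear antiproliferative effect.

Still open, going by these compounds, is whether another group on that aromatic carbon, such as an amine or a longer chain, would shift the read-out on either core. Also open, on these data alone, is how these compounds behave at other concentrations.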